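Cytotoxicity notes: fluoro to methylsulfanyl in the hydrazone series

The compounds below may be only part of what the source reports. "The series", "measured", "known", "first", "only" and "open" are said of these compounds alone.

Of the compounds shown here, three have been measured in an ADME assay on HEL cells (Homo sapiens) for cytotoxicity; a lower number here means that less compound is tolerated, a higher number that more compound is tolerated. Compound 3 `O=C(COc1cccc2ccccc12)N/N=C/c1ccc(F)cc1` gives 71.6 ug/mL, the highest of the three numbers. Compound 1 `O=C(COc1cccc2ccccc12)N/N=C/c1ccccc1Cl` gives 62.7 ug/mL, and compound 2 `O=C(COc1cccc2ccccc12)N/N=C/c1ccccc1O` gives 3.57 ug/mL. The gap between compound 3 and compound 1 is a 1.1-fold higher number from compound 1 to compound 3 (0.06 log units; within the scatter), so the two are not distinguished, whereas the other gap is larger: a 20-fold higher number from compound 2 to compound 3 (1.30 log units; beyond the scatter).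

Compound 4 `CSc1ccc(/C=N/NC(=O)COc2cccc3ccccc23)cc1` differs from compound 3 in one place: methylsulfanyl in place of fluoro on an aromatic carbon. Going by the values given here, the only measured step on the same aromatic ring without a hydroxy group is the one from compound 1 to compound 3, a 1.1-fold higher number from compound 1 to compound 3 (0.06 log units; within the scatter), which lies within the scatter. The large step from compound 1 to compound 2, an 18-fold lower number from compound 1 to compound 2 (1.24 log units; beyond the scatter), involves a hydroxy group; compound 4 carries none, so that step is taken as no guide here. A change in this assay beyond the scatter is therefore not expected, and the estimated step is a 1.2-fold lower number from compound 3 to compound 4 (0.08 log units; within the scatter). For compound 4 the estimate in this assay is 60 ug/mL, with a range from 30 ug/mL to 120 ug/mL.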

Compound 4, half-maximal cytotoxic concentration: > 100 ug/mL
Compound 4 was reported as a limit; the forecaster's own chance of this, stated with the estimate: 10%; middle value at least 1.6-fold (0.22 log units) away from the limit.
By their numbers in this assay, from the lowest: compound 2; then compounds 1 and 3 (each within the scatter of the next). At a limit, above all of these: compound 4.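

In this assay the value of compound 4 is a limit and not a number: the limit of > 100 ug/mL in this assay, at which 1 of the 4 values shown sits.

Methylsulfanyl in place of fluoro on this aromatic carbon, para to a large group, gives an at least 1.3-fold higher number from compound 3 to compound 4 (0.14 log units; that floor lies within the scatter), and the comparison with the 2-chlorophenyl compound gives an at least 1.5-fold higher number from compound 1 to compound 4 (0.20 log units; that floor lies within the scatter), so neither step separates compound 4 from its neighbours. Going by these compounds alone, the one step that clears the scatter is an at least 28-fold higher number from compound 2 to compound 4 (1.44 log units; beyond the scatter), which shows that a sulfur-bearing group at this position does not bring the number down to that of the 2-hydroxyphenyl compound.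

Going by these compounds, the true value of compound 4 stays open, and with it any order among compound 1, compound 3 and compound 4. Also open, on these data alone, is whether an amine or a carboxylic acid at this position, or a longer chain on the sulfur, would hold the number at this level.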